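A few compounds are considered here, and "the series" means these few. Any claim that something is new, unique, unknown or untested is made for them only; others in the source may bear on it.

In an assay on isolated protein for antagonist activity at Bile acid receptor (Homo sapiens), read by HTRF, with a stated time of 30 min (on this read-out lower numbers stand for stronger inhibition and higher numbers for weaker inhibition), the three measured compounds stand as follows:
compound 1 `CCCCc1cc(C(C)=O)c(OCc2ccccc2)cc1OCCCCCC(C)(C)c1nnn[nH]1` gives 7800 nM;
compound 2 `CCc1cc(C(C)=O)c(OCc2ccccc2)cc1OCCCCCC(C)(C)c1nnn[nH]1` gives 1100 nM;
compound 3 `CCCCc1cc(C(C)=O)c(O)cc1OCCCCCC(C)(C)c1nnn[nH]1` gives 1500 nM.

Compound 2 and compound 1 differ in one place, (ethyl in place of hydrogen on a saturated chain carbon, two bonds along the chain from an aromatic carbon), and that change brought a 7.1-fold higher number from compound 2 to compound 1 (0.85 log units; beyond the scatter), a weakening. Compound 1 and compound 3 also differ in one place, a hydrogen in place of benzyl on an oxygen on an aromatic ring, and this step gave a 5.2-fold lower number from compound 1 to compound 3 (0.72 log units; beyond the scatter). The difference between the cores of compound 3 and compound 2 is not broken down here; their values lie within the usual scatter of each other.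

Compound 4 `CCCCCCc1cc(C(C)=O)c(O)cc1OCCCCCC(C)(C)c1nnn[nH]1` differs from compound 3 by ethyl in place of hydrogen on a saturated chain carbon, four bonds along the chain from an aromatic carbon. Among the measured compounds shown here, this is the same kind of change as the one from compound 2 to compound 1, but not the same: there the ethyl entered two bonds along the chain from an aromatic carbon, here it enters four bonds along the chain from an aromatic carbon. A weakening of similar direction is expected, though perhaps smaller, because the earlier instance gave a 7.1-fold higher number from compound 2 to compound 1 (0.85 log units; beyond the scatter) at a different place. Compound 4 is therefore estimated at 5000 nM in this assay, likely between 1800 nM and 15000 nM. That estimate corresponds to an expected step of a 3.3-fold higher number from compound 3 to compound 4 (0.52 log units; beyond the scatter).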

Compound 4, half-maximal inhibitory concentration: 3200 nM
Beside the measured number, compound 4's estimate is 1.6-fold (0.19 log units) above it; low and high end bracket the measured number.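

In this assay, placing ethyl on a saturated chain carbon, four bonds along the chain from an aromatic carbon, gave a 2.1-fold higher number from compound 3 to compound 4 (0.33 log units; beyond the scatter). The change weakened inhibition on both cores, but its size did not carry over: the same change on two cores in this assay, a 7.1-fold higher number (0.85 log units; beyond the scatter) from compound 2 to compound 1 and a 2.1-fold higher number (0.33 log units; beyond the scatter) from compound 3 to compound 4, 3.3-fold (0.52 log units) apart, beyond the scatter of two such steps
These two cases suggest that the direction of this change may carry from one core to another, whereas its size cannot simply be transferred; they do not show what sets the size, since the two steps differ both in where the ethyl enters and in whether the oxygen on the aromatic ring bears benzyl or hydrogen.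

As far as these compounds go, it remains open whether the gap follows the position of the ethyl or the group on that oxygen, and placing ethyl at the same chain position on both cores would separate the two. From the compounds shown here alone, it is also open how a longer chain, or a chain ending in an amine or a carboxylic acid, would fare at this place.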